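Triazole methyl to trifluoromethyl: what the series supports

The source may hold more compounds than are shown below. What is called first, only, known or untested is meant among the compounds shown, and "the series" means these compounds.

Measured in a functional assay on HT-29 cells (Homo sapiens) for cytotoxicity, read by MTT assay, with a stated time of 72 h; on this read-out higher numbers stand for weaker inhibition and lower numbers for stronger inhibition:
- compound 1 `Cc1c(C(=O)Nc2ccc(Oc3ccnc4[nH]ccc34)c(F)c2)nnn1-c1ccccc1` gives 290 nM
- compound 2 `Cc1c(C(=O)Nc2ccc(Oc3ccnc4[nH]ccc34)c(F)c2)nnn1-c1ccccc1F` gives 180 nM
- compound 3 `Cc1c(C(=O)Nc2ccc(Oc3ccnc4[nH]ccc34)c(F)c2)nnn1-c1ccc(F)cc1` gives 120 nM

Compound 1 stands highest of the three numbers. Its step to compound 2 is a 1.6-fold lower number from compound 1 to compound 2 (0.21 log units; within the scatter), and its step to compound 3 is a 2.4-fold lower number from compound 1 to compound 3 (0.38 log units; beyond the scatter). Between the two fluorinated analogues the step is a 1.5-fold lower number from compound 2 to compound 3 (0.18 log units; within the scatter).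

Compound 4 `O=C(Nc1ccc(Oc2ccnc3[nH]ccc23)c(F)c1)c1nnn(-c2ccccc2)c1C(F)(F)F` differs from compound 1 by trifluoromethyl in place of methyl on an aromatic carbon. All three measured steps concern fluoro on the phenyl attached to the ring nitrogen and leave the methyl untouched, so none of them bears directly on this change; they show only that small substitutions elsewhere in the shared core moved the read-out little. With nothing in the series addressing the methyl position, no step beyond the scatter in this assay is expected in either direction, and the range is set wide. Compound 4 is therefore estimated at 260 nM (range 100 nM to 700 nM), an expected step of a 1.1-fold lower number from compound 1 to compound 4 (0.05 log units; within the scatter).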

Compound 4, half-maximal inhibitory concentration: 91 nM
Compound 4: middle estimate off by 2.9-fold (0.46 log units), on the high side; measured number outside the range, below it.
By their numbers in this assay, from the lowest: compounds 4, 3, 2 and 1 (each within the scatter of the next, the first and the last beyond it).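

Within the data shown here, the methyl position on the five-membered aromatic ring responds in this assay: trifluoromethyl in place of methyl gives a 3.2-fold lower number from compound 1 to compound 4 (0.50 log units; beyond the scatter), the only step that touches this carbon. The step is modest, but it lies beyond the scatter, so what sits on this carbon matters to the read-out and trifluoromethyl is accepted here with no loss in inhibition. Nothing shown gives a measured property that would account for this step.

As far as these compounds go, this rests on a single pair carrying the unsubstituted phenyl, so it remains open whether the same change holds with fluoro on that phenyl, as in compound 2 or compound 3. Also open, from the compounds shown here alone, is how other groups on this carbon would read, such as hydrogen, an ethyl chain, a nitrile or an amine.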